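The compounds below may be only part of what the source reports. "The series", "measured", "known", "first", "only" and "open" are said of these compounds alone.

Compound 2 `CCc1ccc(-c2ccc(N(C[C@@H](N)[C@@H](C)CC)C(=O)[C@@H]3C[C@H]3c3ccccc3)cc2)cc1` is the stronger of the two measured compounds in a functional assay for agonist activity at G protein-coupled receptor 88 (Homo sapiens), read by HTRF and cAMP accumulation; a lower number here means that less compound is needed, a higher number that more compound is needed for the effect: compound 2 gives 44 nM, whereas compound 1 `COc1ccccc1-c1ccc(N(C[C@@H](N)CC(C)C)C(=O)[C@@H]2C[C@H]2c2ccccc2)cc1` gives 3200 nM, a gap well beyond the usual scatter. Compound 3 `CC[C@H](C)[C@H](N)CN(C(=O)[C@@H]1C[C@H]1c1ccccc1)c1ccc(-c2ccc(CO)cc2)cc1` has not yet been measured. It differs from compound 2 in one place: hydroxy in place of methyl on a saturated chain carbon bound to an aromatic carbon. Going by the values given here, no pair of measured compounds shows the effect of such a change, so the expectation rests on compound 2 alone. A modest rise in the number is expected, a 3.4-fold higher number from compound 2 to compound 3 (0.53 log units; beyond the scatter), a step that may just exceed the scatter. Compound 3 is therefore estimated at 150 nM, within a range from 30 nM to 700 nM.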

Compound 3, half-maximal effective concentration: 1100 nM
For compound 3 the middle estimate is 7.3-fold (0.87 log units) below the measured one, outside the stated range (above it).
By their numbers in this assay, from the lowest: compound 2; then compound 3; then compound 1.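

Changing 4-ethylphenyl to 4-(hydroxymethyl)phenyl gives a large loss, a 25-fold higher number from compound 2 to compound 3 (1.40 log units; beyond the scatter), although only one heavy atom differs. Going by these compounds alone, this is the first single change that can be read here, as compound 1 and compound 2 differ in more than one place, and it shows that this position does not tolerate every swap of methyl for hydroxy. Nothing available explains the loss.

Going by these compounds, it remains open how other groups would fare at this position. A methoxy, an amine or a longer chain such as propyl could show how narrow the tolerance is.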